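The source may report more compounds than this note shows. Statements on the series, on what has been measured and on what is new or still open speak of the compounds shown alone.

Series on a shared core, compound 1 `O=S(=O)(Nc1ccc(-c2nc3ccccc3o2)cc1)c1cccs1`, compound 2 `Cc1cccc(S(=O)(=O)Nc2ccc(-c3nc4ccccc4o3)cc2)c1` and compound 3 `C=Cc1ccc(S(=O)(=O)Nc2ccc(-c3nc4ccccc4o3)cc2)cc1`, examined in an assay on isolated protein for inhibition of malate dehydrogenase, mitochondrial (Sus scrofa), with stated times of 45 min and 30 min; a higher number here means a weaker inhibitor, a lower number a stronger inhibitor. Compound 1 gives only a limit of the assay, > 63000 nM. Compound 2 likewise gives only a limit, > 63000 nM. Compound 3 also returns only a limit, > 63000 nM. Compound 3 therefore stands exactly where every measured value of the series sits, at the limit of > 63000 nM in this assay, at which 3 of the 3 values shown sit. The steps a step that the two limits leave unreadable from compound 1 to compound 2, a step that the two limits leave unreadable from compound 1 to compound 3 and a step that the two limits leave unreadable from compound 2 to compound 3 are all left unreadable by the two limits, so no size can be attached to exchanging the group on the sulfonyl sulfur within the data so far. Compound 4 `COc1ccccc1S(=O)(=O)Nc1ccc(-c2nc3ccccc3o2)cc1` is not yet measured in this assay; it differs from compound 3 by 2-methoxyphenyl in place of 4-vinylphenyl on a sulfonyl sulfur. The measured steps that bear on this change are the three unreadable ones, each a swap of the group on the sulfonyl sulfur, and none gives a readable size in either direction. Compound 4 is therefore expected to remain at the limit, with a step that the limit leaves unreadable from compound 3 to compound 4 expected not to exceed the scatter. The estimate for compound 4 is 100000 nM, in the range 40000 nM to 300000 nM.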

Compound 4, half-maximal inhibitory concentration: > 63000 nM
Compound 4 was reported as a limit; the forecaster's own chance of this, stated with the estimate: 85%; the middle value does not contradict the limit.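

In this assay compound 4 gives only the limit > 63000 nM and so its steps from compound 1, compound 2 and compound 3 cannot be read: the limit of > 63000 nM in this assay, at which 4 of the 4 values shown sit. The compounds shown leave open whether any group on the sulfonyl sulfur brings a readable inhibition on the shared core.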